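The source may report more compounds than this note shows. Statements on the series, on what has been measured and on what is new or still open speak of the compounds shown alone.

Measured in a functional assay on U-251 cells (Homo sapiens); a lower number here means a stronger inhibitor of growth, a higher number a weaker inhibitor of growth:
Compound 1 `O=S(=O)(/C=C/c1ccc(Cl)c(Cl)c1)Cc1ccc(Nc2ncnc3ccccc23)cc1`: 11000 nM
Compound 2 `O=S(=O)(/C=C/c1ccc(Cl)c(Cl)c1)Cc1ccc(Nc2ncnc3ccc(Br)cc23)cc1`: > 100000 nM

Compound 2 stands at > 100000 nM, which is a limit of the assay and not a number. Compound 3 `O=S(=O)(/C=C/c1ccc(Cl)cc1Cl)Cc1ccc(Nc2ncnc3ccc(Br)cc23)cc1` has the same atoms as compound 2, joined differently: 2,4-dichlorophenyl in place of 3,4-dichlorophenyl on a double-bonded chain carbon bound to a double-bonded chain carbon. In words, 2,4-dichlorophenyl takes the place of 3,4-dichlorophenyl on a double-bonded chain carbon bound to a double-bonded chain carbon.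

Among the measured compounds shown here, the only measured step, an at least 9.0-fold higher number from compound 1 to compound 2 (0.95 log units; beyond the scatter), is a bromo in place of hydrogen elsewhere in the molecule. For the measured compounds named here, it therefore bears on this change only indirectly, and no measured step shows a move of a chlorine. No step beyond the scatter is thus expected in this assay, and compound 3 is expected to remain level with compound 2, whose > 100000 nM is a limit. The expected change is a number no higher from compound 2 to compound 3 (the limit leaves the size open). For compound 3 the estimated value is 100000 nM, with an expected range from 35000 nM to 200000 nM.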

Compound 3, concentration for 50% growth inhibition: 4000 nM
Compound 3: the middle estimate sits 25-fold (1.40 log units) above what was measured; measured number below the stated range.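

In this assay, 2,4-dichlorophenyl in place of 3,4-dichlorophenyl gives an at least 25-fold lower number from compound 2 to compound 3 (1.39 log units; beyond the scatter). The earlier step concerned only the bromo on the shared core, whereas this one shows that, with the same atoms and the same core, the arrangement of the two chlorines on the phenyl alone can carry a large change in growth inhibition. The value of compound 2 is a limit of the assay and not a number, so this step has a lower bound but no fixed size: the limit of > 100000 nM in this assay, at which 1 of the 3 values shown sits.

As far as these compounds go, it remains open whether 2,4-dichlorophenyl would give a similar step on the core of compound 1, which has hydrogen in place of the bromo. Also open, from the compounds shown here alone, is how a fluoro, a methoxy or an amine in place of either chlorine would read in this assay.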